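The source may hold more compounds than are shown below. What is called first, only, known or untested is meant among the compounds shown, and "the series" means these compounds.

Compound 1 `CCc1ccc(-c2nc3c(c(C)nn3-c3ccccc3)c(-c3ccccc3O)c2C#N)cc1` gives 3100 nM
Compound 2 `CCc1ccc(-c2nc3c(c(C)nn3-c3ccccc3)c(-c3ccccc3[N+](=O)[O-])c2C#N)cc1` gives 1200 nM
Compound 3 `CCc1ccc(-c2nc3c(c(C)nn3-c3ccccc3)c(-c3ccccc3C#N)c2C#N)cc1` gives 2400 nM

In a physicochemical assay for solubility, read by spectrophotometry, in phosphate buffer, with a stated time of 18 h, at pH 7.4 (a lower number here means a less soluble compound, a higher number a more soluble compound), compound 2 sits at the low end of this set: a 2.6-fold lower number from compound 1 to compound 2 (0.41 log units; beyond the scatter) separates it clearly, whereas a 2.0-fold higher number from compound 2 to compound 3 (0.30 log units; within the scatter) does not. Among the measured compounds shown here, compound 4 `CCc1ccc(-c2nc3c(c(C)nn3-c3ccccc3)c(-c3ccccc3I)c2C#N)cc1` has iodo in place of nitro on an aromatic carbon and no measured compound carries iodo. For the measured compounds named here, the only guides are swaps at that same place, namely those two steps and a 1.3-fold lower number from compound 1 to compound 3 (0.11 log units; within the scatter) as well, and none of them is large. For this change no step beyond the scatter is therefore expected in this assay at all. The expected step is a 1.2-fold lower number from compound 2 to compound 4 (0.08 log units; within the scatter) as an estimate. For compound 4 the estimate is 1000 nM with an expected range from 400 nM to 2500 nM in this read-out.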

Compound 4, solubility: 8500 nM
Compound 4: the middle estimate sits 8.5-fold (0.93 log units) below what was measured, outside the stated range (above it).
By their numbers in this assay, from the lowest: compounds 2, 3 and 1 (each within the scatter of the next, the first and the last beyond it); then compound 4.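

In this assay iodo stands clear of all three other groups at this place, with steps of (a 7.1-fold higher number from compound 2 to compound 4 (0.85 log units; beyond the scatter)), (a 3.5-fold higher number from compound 3 to compound 4 (0.55 log units; beyond the scatter)) and (a 2.7-fold higher number from compound 1 to compound 4 (0.44 log units; beyond the scatter)). Compound 4 is therefore the highest of the set, and this place can move the number further than hydroxy, nitro and cyano had shown. Nothing measured here explains the result. From the compounds shown here alone, whether the rise belongs to iodo alone stays open. Chloro or bromo at this place would test that, while an amine or a carboxylic acid would show how far the range extends.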